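The source may report more compounds than this note shows. Statements on the series, on what has been measured and on what is new or still open speak of the compounds shown alone.

Measured so far:
- compound 1, `CCCCn1ccc2cc(/C(C)=C/C(=O)Nc3ccccc3OCCCC(=O)O)ccc21`: 43 nM
- compound 2, `CCCC(C(C)C)n1ccc2cc(/C(C)=C/C(=O)Nc3ccccc3OCCCC(=O)O)ccc21`: 7.2 nM
- compound 3, `CCCCC(CCCC)n1ccc2cc(/C(C)=C/C(=O)Nc3ccccc3OCCCC(=O)O)ccc21`: 21 nM

All three numbers come from an assay on Prostate gland for inhibition of steroid 5-alpha-reductase (Rattus norvegicus); on this read-out lower numbers stand for stronger inhibition and higher numbers for weaker inhibition. Compound 3 stands second highest of the three: compound 1 sits nearest, with a 2.0-fold lower number from compound 1 to compound 3 (0.31 log units; beyond the scatter) separating them, while compound 2 lies furthest, with a 2.9-fold higher number from compound 2 to compound 3 (0.46 log units; beyond the scatter) between them. The remaining step, a 6.0-fold lower number from compound 1 to compound 2 (0.78 log units; beyond the scatter), is the largest in the set.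

Compound 4, `CCCCCC(CCCCC)n1ccc2cc(/C(C)=C/C(=O)Nc3ccccc3OCCCC(=O)O)ccc21`, differs from compound 3 in one place: 1-pentylhexyl in place of 1-butylpentyl on an aromatic nitrogen. Among the compounds with values here, two measured steps bear on this change, both on the aromatic nitrogen. From compound 1 to compound 3 the number fell, a 2.0-fold lower number from compound 1 to compound 3 (0.31 log units; beyond the scatter), whereas from compound 2 to compound 3 it rose, a 2.9-fold higher number from compound 2 to compound 3 (0.46 log units; beyond the scatter). Growing the branched chain thus pulls in opposite directions, and no measured pair shows what a further lengthening does. The expected step from compound 3 to compound 4 is therefore small, a 1.4-fold higher number from compound 3 to compound 4 (0.15 log units; within the scatter), close to the scatter and leaning toward a slightly higher number. For compound 4 in this assay the estimate is 30 nM, with a range from 10 nM to 90 nM.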

Compound 4, half-maximal inhibitory concentration: 25 nM
Compound 4: the middle estimate sits 1.2-fold (0.08 log units) above what was measured, within the range that was stated.
By their numbers in this assay, from the lowest: compound 2; then compounds 3, 4 and 1 (each within the scatter of the next, the first and the last beyond it).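

In this assay, 1-pentylhexyl in place of 1-butylpentyl on the aromatic nitrogen gives no step beyond the scatter (a 1.2-fold higher number from compound 3 to compound 4 (0.08 log units; within the scatter)), so adding to the two chains of this branched group leaves the read-out unresolved from compound 3. The 1-pentylhexyl group also stays within the scatter of butyl (a 1.7-fold lower number from compound 1 to compound 4 (0.24 log units; within the scatter)) but remains apart from 1-isopropylbutyl (a 3.5-fold higher number from compound 2 to compound 4 (0.54 log units; beyond the scatter)), and among the four groups shown, only 1-isopropylbutyl stands beyond the scatter from all the others. No evidence at hand bears on the reason for this.

Open at this nitrogen are groups with a ring, such as cyclohexylmethyl, and chains carrying an ether or an amine. Also open, from the compounds shown here alone, is how a tetrazole in place of the carboxylic acid would read on the shared core.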